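This account rests on a few compounds, and the source may have more. Where it says the series, first, only, none or still open, it means among the compounds named here.

Compound 1 `Cc1nc(C(N)=O)c(N)c2c1C(=O)N(Cc1ccccc1)C2=O`: < 5000 nM, a limit.
Compound 2 `Cc1nc(C(=O)N(C)C)c(N)c2c1C(=O)N(Cc1ccccc1)C2=O`: 172000 nM.
Compound 3 `Cc1noc(-c2nc(C)c3c(c2N)C(=O)N(Cc2ccccc2)C3=O)n1`: < 5000 nM, a limit.

In a physicochemical assay for solubility, using the shake flask method, in simulated intestinal fluid, measured as kinetic solubility, with a stated time of 2 h, at 25 degrees C, at pH 6.5 (on this read-out lower numbers stand for lower solubility and higher numbers for higher solubility), compound 1 gives < 5000 nM. This is a limit and not a number. Compound 1 stands at the limit of < 5000 nM in this assay, at which 2 of the 3 values shown sit, and compound 3 is the other compound there. Among the measured compounds shown here, the only readable number in the set lies at the end of an at least 34-fold higher number from compound 1 to compound 2 (1.53 log units; beyond the scatter).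

Compound 4 `Cc1nc(-c2nc(C(F)(F)F)no2)c(N)c2c1C(=O)N(Cc1ccccc1)C2=O` carries 3-(trifluoromethyl)-1,2,4-oxadiazol-5-yl in place of carbamoyl on an aromatic carbon, next to the ring nitrogen and ortho to an amino group: 3-(trifluoromethyl)-1,2,4-oxadiazol-5-yl in place of carbamoyl on an aromatic carbon.

For the measured compounds named here, the closest measured change is the one to compound 3, which also replaces carbamoyl with a 1,2,4-oxadiazol-5-yl group, here bearing methyl. That change is a step that the two limits leave unreadable from compound 1 to compound 3, so it gives no size. The other step into compound 3 is an at least 34-fold lower number from compound 2 to compound 3 (1.53 log units; beyond the scatter), but it starts from dimethylcarbamoyl and not from carbamoyl. Together these steps place the oxadiazole compound 3 at the same limit as compound 1, so no step beyond the scatter is expected for compound 4 in this assay, and a report as a limit is the likeliest outcome.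

The estimated change is a step that the limit leaves unreadable from compound 1 to compound 4. The estimate for compound 4 is 3000 nM. The expected range for compound 4 runs from 1000 nM to 9000 nM.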

Compound 4, solubility: < 5000 nM
Compound 4 ended at the assay's limit; the forecaster's own chance of this, stated with the estimate: 80%; the middle value lies beyond the limit too.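

In this assay compound 4 gives < 5000 nM, which is a limit and not a number. With trifluoromethyl in place of methyl on the 1,2,4-oxadiazole, compound 4 joins compound 1 and compound 3 at the same limit, and the steps among these three cannot be read: the limit of < 5000 nM in this assay, at which 3 of the 4 values shown sit. The one readable step is an at least 34-fold lower number from compound 2 to compound 4 (1.53 log units; beyond the scatter), so a second oxadiazole at this place on the aromatic carbon ends at the limit, and dimethylcarbamoyl, in compound 2, remains the only group shown here with a readable number.

Going by these compounds, how far compound 1, compound 3 and compound 4 lie from one another behind the limit stays open, and so does whether trifluoromethyl in place of methyl changes the read-out at all. On these data alone, it is also open whether the readable number in compound 2 belongs to dimethylcarbamoyl alone or would also appear with another group at this place, such as a pyrrolidine amide or a carboxylic acid.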